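Carbamoyl on a ring-nitrogen chain: a solubility comparison

The source may report more compounds than this note shows. Statements on the series, on what has been measured and on what is new or still open speak of the compounds shown alone.

Compound 1 `COc1cc2c(cc1NS(=O)(=O)c1cccc(Cl)c1Cl)[nH]c(=O)n2C` and compound 3 `COc1cc2[nH]c(=O)n(C)c2cc1NS(=O)(=O)c1cccc(Cl)c1Cl` are made of the same atoms joined differently; the difference between the two cores is not broken down here. Among the compounds with values here, in a physicochemical assay for solubility, read by chemiluminescence, measured as kinetic solubility (a lower number here means a less soluble compound, a higher number a more soluble compound), compound 1 gives 12 ug/mL, whereas compound 3 gives 66 ug/mL, the highest of the three numbers measured so far and beyond the scatter from both of the others.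

Compound 2 `COc1cc2c(cc1NS(=O)(=O)c1cccc(Cl)c1Cl)[nH]c(=O)n2CC(N)=O` arises from compound 1 by a single change, (carbamoyl in place of hydrogen on a saturated chain carbon bound to an aromatic nitrogen). In this assay compound 2 gives 11 ug/mL. The step of a 1.1-fold lower number from compound 1 to compound 2 (0.04 log units; within the scatter) lies within the scatter, so compound 1 and compound 2 cannot be told apart on this read-out.

Compound 4 `COc1cc2[nH]c(=O)n(CC(N)=O)c2cc1NS(=O)(=O)c1cccc(Cl)c1Cl` has not yet been measured. Within the data shown here, it arises from compound 3 by carbamoyl in place of hydrogen on a saturated chain carbon bound to an aromatic nitrogen, the same change at the same place as the one that turns compound 1 into compound 2; among the four compounds this change occurs twice, once measured and once not. The expectation for compound 4 rests on that one measured instance: because the step of a 1.1-fold lower number from compound 1 to compound 2 (0.04 log units; within the scatter) left the number essentially where it was, the step from compound 3 to compound 4 is estimated to be similarly small, a 1.1-fold lower number from compound 3 to compound 4 (0.06 log units; within the scatter). On that basis compound 4 is expected to give about 58 ug/mL in this assay, most likely between 25 ug/mL and 130 ug/mL. A single prior example is a thin basis, so the range is kept wide.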

Compound 4, solubility: 167 ug/mL
Beside the measured number, compound 4's estimate is 2.9-fold (0.46 log units) below it; the measured number lies above the stated range.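

In this assay the change from methyl to carbamoylmethyl on the core of compound 3 gives a 2.5-fold higher number from compound 3 to compound 4 (0.40 log units; beyond the scatter) while the same change on the core of compound 1 gives a 1.1-fold lower number from compound 1 to compound 2 (0.04 log units; within the scatter) and so the two measured pairs do not have the same outcome. This shows that, in this series, a step read on one core cannot simply be copied onto the other: one pair shows a modest rise that stands clear of the scatter, and the other shows no change that can be told from it, but two pairs are too few to show how either core would respond to any other change. Nothing available here explains why the same change behaves differently on the two cores.

The compounds shown leave open whether a different group at this place, such as a carboxylic acid, an amine or a longer chain ending in carbamoyl, would also separate the two cores in this way. They also leave open whether the rise seen from carbamoylmethyl on the core of compound 3 is particular to that group or would recur with such relatives.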